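The compounds below may be only part of what the source reports. "The series", "measured", "known", "first", "only" and "open" are said of these compounds alone.

Measured so far:
- compound 1, `CCCCN(CC)c1nc(C)nc2c1ncn2-c1ccc(C(C)C)cc1Br`: 4.3 nM
- compound 2, `CCCC(CCC)Nc1nc(C)nc2c1ncn2-c1ccc(C(C)C)cc1Br`: 3.6 nM

Both compounds were tested in an in vitro assay on 293-EBNA cells for binding affinity to corticotropin-releasing factor receptor 1 (Homo sapiens); on this read-out lower numbers stand for stronger inhibition and higher numbers for weaker inhibition. Compound 1 gives 4.3 nM, the higher of the two numbers; its nearest neighbour, compound 2, gives 3.6 nM, and the step of a 1.2-fold lower number from compound 1 to compound 2 (0.08 log units; within the scatter) is within the scatter, so the two cannot be told apart.

Compound 3, `CCCCN(CC)c1nc(C)nc2c1nc(C)n2-c1ccc(C(C)C)cc1Br`, has not yet been measured. It differs from compound 1 in one place: methyl in place of hydrogen on an aromatic carbon. The change sits on an aromatic carbon of the five-membered aromatic ring with two nitrogens, part of a fused system of two rings, between the two ring nitrogen atoms.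

Among the measured compounds shown here, the single measured step, from compound 1 to compound 2, concerns the amino group and not this ring carbon, so it does not bear on the change in question. For the measured compounds named here, no step in the data addresses adding a group on the shared core. Without such a comparison, no shift beyond the scatter is expected in either direction, but the uncertainty is wide. Compound 3 is therefore estimated at 5 nM, in a range from 1.5 nM to 20 nM, which means an expected step of a 1.2-fold higher number from compound 1 to compound 3 (0.07 log units; within the scatter).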

Compound 3, inhibition constant: 0.9 nM
Compound 3: middle estimate off by 5.6-fold (0.74 log units), on the high side, outside the stated range (below it).
By their numbers in this assay, from the lowest: compound 3; then compounds 2 and 1 (each within the scatter of the next).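

In this assay, among the compounds shown here, the aromatic carbon between two ring nitrogen atoms proves to be a place where a very small change counts: methyl in place of hydrogen brings a 4.8-fold lower number from compound 1 to compound 3 (0.68 log units; beyond the scatter) and thus the first separation between two compounds in this short series. For the compounds shown here, the only earlier step, a 1.2-fold lower number from compound 1 to compound 2 (0.08 log units; within the scatter) in the amino group, stayed within the scatter, so it gave no sign that one added carbon on the shared core could matter more than that exchange of amino groups. No measurement presented here explains the lower number, so the finding remains an observation about this single pair of compounds.

What the compounds shown leave open is whether the effect belongs to methyl itself or extends to other groups on this carbon, such as ethyl, a longer chain, chlorine or an amine, any of which could lower the number further, leave it unchanged or raise it. From the compounds shown here alone, it is also open whether the same methyl would lower the number when the (1-propylbutyl)amino group of compound 2 stands in place of the butyl(ethyl)amino group.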